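Isopropyl for acetyl on a spiro-thiazine anilide

A few compounds are considered here, and "the series" means these few. Any claim that something is new, unique, unknown or untested is made for them only; others in the source may bear on it.

The measured compounds and their values:
compound 1 `c1ccc(NC2=NCCC3(CCCCC3)S2)cc1` gives 63100 nM in a functional assay on a subcellular fraction from brain (Rattus norvegicus) for inhibition, read by scintillation counting, with a stated time of 5 min; on this read-out lower numbers stand for stronger inhibition and higher numbers for weaker inhibition;
compound 2 `Cc1ccc(NC2=NCCC3(CCCCC3)S2)cc1Cl` gives 89100 nM in this assay;
compound 3 `CC(=O)c1ccc(NC2=NCCC3(CCCCC3)S2)cc1` gives 81300 nM in this assay.

Compound 3 stands second highest of the three numbers, within the scatter of both compound 2 and compound 1. Compound 4 `CC(C)c1ccc(NC2=NCCC3(CCCCC3)S2)cc1` differs from compound 3 by isopropyl in place of acetyl on an aromatic carbon. Within the data shown here, the one step that bears on this position is a 1.3-fold higher number from compound 1 to compound 3 (0.11 log units; within the scatter), which lies within the scatter; the numbers of compound 2 and compound 3 likewise lie within the scatter of each other. No step beyond the scatter is therefore expected in this assay from compound 3 to compound 4, and compound 4 is estimated at 70000 nM, in a range of 30000 nM to 160000 nM. The step this estimate means for compound 4 is a 1.2-fold lower number from compound 3 to compound 4 (0.06 log units; within the scatter).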

Compound 4, half-maximal inhibitory concentration: 6200 nM
The estimate for compound 4 lay 11-fold (1.05 log units) above the measured number; the measured number lies below the stated range.
By their numbers in this assay, from the lowest: compound 4; then compounds 1, 3 and 2 (each within the scatter of the next).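

In this assay this position proves able to move the number far: isopropyl in place of acetyl gives a 13-fold lower number from compound 3 to compound 4 (1.12 log units; beyond the scatter), and isopropyl in place of hydrogen gives a 10-fold lower number from compound 1 to compound 4 (1.01 log units; beyond the scatter). Acetyl in place of hydrogen had given only a 1.3-fold higher number from compound 1 to compound 3 (0.11 log units; within the scatter), so the position responds to isopropyl but not to every group placed there. Nothing measured here accounts for this difference.

On these data alone, what ethyl, tert-butyl or an amine would give at this place stays open, as does whether isopropyl would give a like step elsewhere on the aromatic ring.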